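The compounds below may be only part of what the source reports. "The series", "measured", "known", "first", "only" and "open" are said of these compounds alone.

Compound 1 `COC(=O)C(C)(C)NC(=O)c1cc(F)cc2cc(-c3ccc(Cl)cc3)oc12`: > 10000 nM
Compound 2 `C[C@H](NC(=O)c1cc(F)cc2cc(-c3ccc(Cl)cc3)oc12)C(=O)O`: 4440 nM
Compound 3 `O=C(NC1(C(=O)O)CC1)c1cc(F)cc2cc(-c3ccc(Cl)cc3)oc12`: 1120 nM

In an assay on isolated protein for inhibition of endoplasmic reticulum aminopeptidase 1 (Homo sapiens), with stated times of 15 min and 20 min (on this read-out lower numbers stand for stronger inhibition and higher numbers for weaker inhibition), compound 1 gives only a limit, > 10000 nM, so no number is known for it (the limit of > 10000 nM in this assay, at which 1 of the 3 values shown sits). Compound 4 `O=C(NC1(C(=O)O)CCCC1)c1cc(F)cc2cc(-c3ccc(Cl)cc3)oc12` differs from compound 1 by 1-carboxycyclopentyl in place of 1-(methoxycarbonyl)-1-methylethyl on an amide-type nitrogen. Going by the values given here, three measured steps bear on this change. Replacing the ester group of compound 1 with an acid gave an at least 2.2-fold lower number from compound 1 to compound 2 (0.35 log units; beyond the scatter), and the ring-bearing acid gave an at least 8.9-fold lower number from compound 1 to compound 3 (0.95 log units; beyond the scatter); between the two acids there was a 4.0-fold lower number from compound 2 to compound 3 (0.60 log units; beyond the scatter). Compound 4 carries an acid on a ring, like compound 3, so a lower number than the limit of compound 1 is expected, roughly an at least 6.6-fold lower number from compound 1 to compound 4 (0.82 log units; beyond the scatter). The estimate for compound 4 is 1500 nM, within 500 nM to 5000 nM.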

Compound 4, half-maximal inhibitory concentration: 99 nM
Beside the measured number, compound 4's estimate is 15-fold (1.18 log units) above it, and the stated range ends above it.
By their numbers in this assay, from the lowest: compound 4; then compound 3; then compound 2. At a limit, above all of these: compound 1.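

Among the acids, the ring makes a clear difference: moving to 1-carboxycyclopentyl gives an 11-fold lower number from compound 3 to compound 4 (1.05 log units; beyond the scatter) and a 45-fold lower number from compound 2 to compound 4 (1.65 log units; beyond the scatter), so a carbon ring at this place does far more than compound 3 alone suggested. The step from the ester reads an at least 100-fold lower number from compound 1 to compound 4 (2.00 log units; beyond the scatter), and compound 1 itself gives only a limit: the limit of > 10000 nM in this assay, at which 1 of the 4 values shown sits.

Going by these compounds, since that step swaps both the ester and the ring, the share of each stays unknown; the methyl ester of 1-carboxycyclopentyl would separate them. On these data alone, whether 1-carboxycyclohexyl would lower the number further also remains open.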